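Chloro for methoxy on a cinnamate ester anilide

The source may report more compounds than this note shows. Statements on the series, on what has been measured and on what is new or still open speak of the compounds shown alone.

Of the compounds shown here, two have been measured in a functional assay on HeLa cells (Homo sapiens) for cytotoxicity, read by MTT assay, with a stated time of 72 h; on this read-out lower numbers stand for stronger inhibition and higher numbers for weaker inhibition. Compound 1 `O=C(/C=C/c1ccccc1)NNC(=O)c1ccccc1O` gives 73100 nM, and compound 2 `COCOc1cc(/C=C/C(=O)OCC(=O)Nc2ccc(OC)cc2)ccc1OCc1ccccc1` gives 155000 nM. Compound 2 thus stands at the higher of the two numbers, with compound 1 the nearer and lower one by a gap beyond the usual scatter. Compound 3 `COCOc1cc(/C=C/C(=O)OCC(=O)Nc2ccc(Cl)cc2)ccc1OCc1ccccc1` is not yet measured; it differs from compound 2 in one place, (chloro in place of methoxy on an aromatic carbon), chloro in place of methoxy on an aromatic carbon. No step of this kind has been measured in this assay among the compounds shown, so there is nothing to calibrate the change against. The account expects a step from compound 2 to compound 3 that is small and of uncertain direction, a 1.3-fold lower number from compound 2 to compound 3 (0.11 log units; within the scatter), likely not beyond the scatter. For compound 3 the estimated value in this assay is 120000 nM, with a range from 50000 nM to 300000 nM.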

Compound 3, half-maximal inhibitory concentration: > 200000 nM
Compound 3: a limit, no number; the forecaster's own chance of this, stated with the estimate: 20%; middle value at least 1.6-fold (0.22 log units) from the limit.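

In this assay compound 3 carries a limit and not a number: the limit of > 200000 nM in this assay, at which 1 of the 3 values shown sits. For the compounds shown here, the change from 4-methoxyphenyl to 4-chlorophenyl is the only step read at this position, and it gives an at least 1.2-fold higher number from compound 2 to compound 3 (0.11 log units; that floor lies within the scatter). As far as these compounds go, it offers no sign that chloro in place of methoxy lowers the number on this read-out, but only a floor for the step is fixed, so its true size remains unknown.

The compounds shown leave open whether another group at this position, such as fluoro, an amine or a carboxylic acid, would give a number that can be read within the range of the assay. They also leave open whether a hydroxyl in place of the benzyloxy group on the shared core would change the number at all.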